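The source may report more compounds than this note shows. Statements on the series, on what has been measured and on what is new or still open speak of the compounds shown alone.

Compound 1 `CCN1CCN(c2cc(C)c3cc(NC(=O)c4ccccc4C)ccc3n2)CC1` gives the highest of the three numbers in a functional assay on MCF7 cells (Homo sapiens) for antiproliferative activity, read by MTT assay, with a stated time of 72 h (on this read-out higher numbers stand for weaker inhibition and lower numbers for stronger inhibition), at 10900 nM. Compound 2 `CCN1CCN(c2cc(C)c3cc(NC(=O)c4ccc(OC)cc4)ccc3n2)CC1` gives 7690 nM in this assay, and compound 3 `CCN1CCN(c2cc(C)c3cc(NC(=O)c4ccc(Cl)c(Cl)c4)ccc3n2)CC1` gives 1380 nM. The step of a 1.4-fold lower number from compound 1 to compound 2 (0.15 log units; within the scatter) stays within the scatter, whereas a 7.9-fold lower number from compound 1 to compound 3 (0.90 log units; beyond the scatter) and a 5.6-fold lower number from compound 2 to compound 3 (0.75 log units; beyond the scatter) go beyond it. Compound 4 `CCN1CCN(c2cc(C)c3cc(NC(=O)c4ccc(C)cc4)ccc3n2)CC1` differs from compound 1 by 4-methylphenyl in place of 2-methylphenyl on a carbonyl carbon. The step that bears most on this change is a 1.4-fold lower number from compound 1 to compound 2 (0.15 log units; within the scatter), since there too only the group on the carbonyl carbon was exchanged and the number hardly moved; the larger steps to compound 3 involve a different group. Compound 4 is therefore expected to show a 1.5-fold lower number from compound 1 to compound 4 (0.16 log units; within the scatter), not clearly beyond the scatter, with an estimated value of 7500 nM, ranging from 3000 nM to 18000 nM.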

Compound 4, half-maximal inhibitory concentration: 6740 nM
Estimate against measurement, compound 4: 1.1-fold (0.05 log units) above, and the stated range covers the measured number.
By their numbers in this assay, from the lowest: compound 3; then compounds 4, 2 and 1 (each within the scatter of the next).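

In this assay, 4-methylphenyl in place of 2-methylphenyl on a carbonyl carbon, the same atoms joined differently, gives a 1.6-fold lower number from compound 1 to compound 4 (0.21 log units; within the scatter) and so stays within the scatter. Methyl in place of methoxy on an aromatic carbon gives a 1.1-fold lower number from compound 2 to compound 4 (0.06 log units; within the scatter), so these two groups are not told apart here, whereas a 4.9-fold higher number from compound 3 to compound 4 (0.69 log units; beyond the scatter) leaves the 3,4-dichlorophenyl group of compound 3 standing apart from the 4-methylphenyl group. Going by these compounds, whether 4-chlorophenyl or 3-chlorophenyl alone would match 3,4-dichlorophenyl stays open, as does the effect of an amine on this ring. No measured evidence explains any of these steps.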